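This account rests on a few compounds, and the source may have more. Where it says the series, first, only, none or still open, it means among the compounds named here.

Series notes. Compound 1 `Cc1ccnc2nc(-c3cccc(Cl)c3)cc(O)c12` is the parent of the first pair; in a functional assay on cells (Tumor Cell line, Homo sapiens) for antiproliferative activity (on this read-out higher numbers stand for weaker inhibition of growth and lower numbers for stronger inhibition of growth), compound 1 gives 158 nM. Compound 2 `Cc1cc(C)c2c(O)cc(-c3cccc(Cl)c3)nc2n1` carries one more methyl; in this assay compound 2 gives 347 nM. The change between them is methyl in place of hydrogen on an aromatic carbon and the step is a 2.2-fold higher number from compound 1 to compound 2 (0.34 log units; beyond the scatter). Compound 3 `Cc1ccc2c(O)cc(-c3ccc4ccccc4c3)nc2n1` has a different core; the difference between the two cores is not broken down here. In this assay compound 3 gives 4570 nM, the highest number of the three measured. Compound 4 `Cc1cc(C)c2c(O)cc(-c3ccc4ccccc4c3)nc2n1` is not yet measured; it differs from compound 3 by methyl in place of hydrogen on an aromatic carbon. This is the same kind of change as in the first pair, but the place is not described in the same words: in the first pair the entering methyl is next to the ring nitrogen and para to a fused ring, in the second it is ortho to a fused ring and opposite the ring nitrogen; both places are meta to a fused ring and meta to a methyl group. For compound 4 the expected step is a 2.0-fold higher number from compound 3 to compound 4 (0.29 log units; within the scatter), resting on the earlier step of the same kind. The range is kept wide; the surroundings of the place differ. Estimate for compound 4 in this assay: 9000 nM, plausibly between 3500 nM and 25000 nM.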

Compound 4, concentration for 50% growth inhibition: 13500 nM
Beside the measured number, compound 4's estimate is 1.5-fold (0.18 log units) below it; low and high end bracket the measured number.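

In this assay, methyl in place of hydrogen on an aromatic carbon again goes with weaker inhibition of growth, with a 3.0-fold higher number from compound 3 to compound 4 (0.47 log units; beyond the scatter). Across the two cores the step keeps its direction, and its size holds within the scatter: the same change on two cores in this assay, a 2.2-fold higher number (0.34 log units; beyond the scatter) from compound 1 to compound 2 and a 3.0-fold higher number (0.47 log units; beyond the scatter) from compound 3 to compound 4, 1.3-fold (0.13 log units) apart, within the scatter of two such steps. This shows that the change carried over between these two pairs, even though the surroundings of the entering methyl are not the same in each; it does not show that the step would hold on a further core, and two pairs give no reason for it.

Open, going by these compounds, is whether the higher number belongs to methyl alone or would also come with a longer chain such as ethyl, or with a different group such as an amine or a carboxylic acid at the same place. Also open, on these data alone, is whether any group there would lower the number rather than raise it.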